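From Isopropyl to Methoxymethyl in a Flat Series

The source may hold more compounds than are shown below. What is called first, only, known or untested is meant among the compounds shown, and "the series" means these compounds.

Of the compounds shown here, three have so far been tested in an assay on isolated protein (strain Sprague-Dawley) for inhibition of Amine oxidase [flavin-containing] A (Rattus norvegicus), read by spectrophotometry, with a stated time of 5 min, tested at 10 uM; a higher number here means more inhibition at the concentration tested (going by the name of the read-out), a lower number less inhibition. Compound 1 `O=c1cc(O)c2ccc(OCc3cccc(F)c3)cc2o1` gives 0% in this assay. Compound 2 `CCOc1cc(=O)oc2cc(OCc3cccc(Cl)c3)ccc12` gives 2%. Compound 3 `CC(C)Oc1cc(=O)oc2cc(OCc3cccc(Cl)c3)ccc12` gives 3%, the highest of the three numbers, although its distance to compound 2 and its distance to compound 1 both fall within the usual scatter, so no order among the three can be claimed. Among the compounds with values here, the single step between compounds that differ in one place, a number 1 percentage points higher from compound 2 to compound 3 (within the scatter), brings methyl in place of hydrogen on a saturated chain carbon bound to an oxygen on an aromatic ring and a saturated chain carbon, and it changes nothing beyond the scatter.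

Compound 4 `COCOc1cc(=O)oc2cc(OCc3cccc(Cl)c3)ccc12` is the next compound awaiting measurement in this assay. It differs from compound 3 in one place: methoxymethyl in place of isopropyl on an oxygen on an aromatic ring. Within the data shown here, the only measured step that bears on this change is a number 1 percentage points higher from compound 2 to compound 3 (within the scatter), which also reshaped the group on the oxygen on the aromatic ring and stayed within the scatter. On that basis the expected change, no change at the digits printed from compound 3 to compound 4 (within the scatter), is no step beyond the scatter in either direction. Compound 4 is therefore estimated at 3%, with a range from -5% to 12%.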

Compound 4, a percentage reported as inhibition, at one concentration (the size of the read-out at that concentration, not a potency): 23%
Beside the measured number, compound 4's estimate is 20 percentage points below it, outside the stated range (above it).
By their numbers in this assay, from the lowest: compounds 1, 2 and 3 (each within the scatter of the next); then compound 4.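

In this assay, within the data shown here, the group on the oxygen on the aromatic ring turns out to matter: methoxymethyl in place of isopropyl gives a number 20 percentage points higher from compound 3 to compound 4 (beyond the scatter) and is the first change to leave the scatter, although both groups carry 3 heavy atoms and no ring. Methoxy in place of methyl on the saturated chain carbon gives a number 21 percentage points higher from compound 2 to compound 4 (beyond the scatter) as well, whereas the methyl added between the ethoxy of compound 2 and the isopropoxy of compound 3 gave only a number 1 percentage points higher from compound 2 to compound 3 (within the scatter) and so moved nothing, which means that among these three compounds only the one whose group holds a hydrogen-bond acceptor stands apart. Nothing available accounts for this rise.

Going by these compounds, whether the rise belongs to the methoxymethyl group alone remains open, since a longer chain such as methoxyethyl, or an amine on the same oxygen, would be needed to show how far it extends. On these data alone, compound 4 at 23% is also a reading at one concentration, so its potency remains unknown.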